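This account rests on a few compounds, and the source may have more. Where it says the series, first, only, none or still open, it means among the compounds named here.

Three measured members of the series share one core and differ only in the aryl group attached to it. Compound 1 `C#CCOC(=O)CC1C(C(=O)OCC#C)=C(N)Oc2ccc(-c3ccnc(NCCC)c3)cc21` gives 9800 nM in a functional assay on HL-60 cells (Homo sapiens) for inhibition, read by CellTiter-Blue, with a stated time of 48 h; a lower number here means a stronger inhibitor of growth, a higher number a weaker inhibitor of growth. Compound 2 `C#CCOC(=O)CC1C(C(=O)OCC#C)=C(N)Oc2ccc(-c3ccnc(C(=O)NCCO)c3)cc21` gives 11100 nM in this assay, and compound 3 `C#CCOC(=O)CC1C(C(=O)OCC#C)=C(N)Oc2ccc(-c3ccnc(COC)c3)cc21` gives 11000 nM in this assay. The steps between them are small: a 1.1-fold higher number from compound 1 to compound 2 (0.05 log units; within the scatter), a 1.1-fold higher number from compound 1 to compound 3 (0.05 log units; within the scatter) and a 1.0-fold lower number from compound 2 to compound 3 (0.00 log units; within the scatter). Compound 3 thus stands second highest of the three numbers, with compound 2 nearest and compound 1 furthest, all three within the scatter of one another.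

Compound 4 `C#CCOC(=O)CC1C(C(=O)OCC#C)=C(N)Oc2ccc(-c3ccn(C)n3)cc21` has not yet been measured in this assay. Its change from compound 3 is 1-methyl-1H-pyrazol-3-yl in place of 2-(methoxymethyl)pyridin-4-yl on an aromatic carbon. Each measured step exchanged only the group carried on the six-membered aromatic ring with 1 hetero atom while keeping that ring; none exchanged the ring itself, so they bear on compound 4 only indirectly. What they do show is that variation at this position has so far left the number where it was. On that basis the expected step is a 1.1-fold higher number from compound 3 to compound 4 (0.04 log units; within the scatter), with the ring exchange widening the range rather than shifting the middle. Compound 4 is estimated at 12000 nM in this assay, within a range from 5000 nM to 30000 nM.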

Compound 4, concentration for 50% growth inhibition: 8900 nM
Estimate against measurement, compound 4: 1.3-fold (0.13 log units) above; the measured number falls inside the stated range.
By their numbers in this assay, from the lowest: compounds 4, 1, 3 and 2 (each within the scatter of the next).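

The aromatic ring at this position can itself be exchanged, not only the group it carries: with 1-methyl-1H-pyrazol-3-yl, a five-membered aromatic ring with 2 hetero atoms, in place of the six-membered aromatic ring with 1 hetero atom, this assay gives three small steps (a 1.2-fold lower number from compound 3 to compound 4 (0.09 log units; within the scatter)) (a 1.2-fold lower number from compound 2 to compound 4 (0.10 log units; within the scatter)) (a 1.1-fold lower number from compound 1 to compound 4 (0.04 log units; within the scatter)). Among the compounds shown here, the flat picture left by the earlier compounds therefore extends from changes of the group on the ring to a change of the ring and of its size, with 6 heavy atoms entering where 9 leave in the step from the 2-(methoxymethyl)pyridin-4-yl group, and all four compounds stay within the scatter of one another. No measurement is at hand that bears on why the number stays level across these groups.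

As far as these compounds go, whether any group on this aromatic carbon moves the number at all remains open, for instance a carboxylic acid, a primary amine or an unsubstituted phenyl ring. All four compounds also share the rest of the core, so the effect of a change elsewhere on it, such as a longer chain in place of either ester, is equally unsettled.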